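Adding one methyl to a compound cells tolerate

The source may hold more compounds than are shown below. What is called first, only, known or untested is meant among the compounds shown, and "the series" means these compounds.

Measured so far in an ADME assay on Vero cells (Chlorocebus sabaeus) for cytotoxicity (a lower number here means that less compound is tolerated, a higher number that more compound is tolerated), are two compounds
- compound 1 `c1cc2c(c(-c3nn4cnnc4s3)c1)OCC2` gives > 50000 nM as a limit
- compound 2 `COc1ccccc1-c1nc2ccncc2s1` gives > 50000 nM as a limit

Compound 2 gives > 50000 nM as a limit of the assay and not as a number. The whole picture so far is the limit of > 50000 nM in this assay, at which 2 of the 2 values shown sit, and nothing finer.

Compound 3 `CCOc1ccccc1-c1nc2ccncc2s1` carries one change from compound 2, namely methyl in place of hydrogen on a saturated chain carbon bound to an oxygen on an aromatic ring which turns methoxy into ethoxy. Going by the values given here, no measured pair shows what such a change does in this assay so no step beyond the usual scatter is expected, in either direction. The expected step of a number no higher from compound 2 to compound 3 (the limit leaves the size open) is therefore small. This expectation rests on compound 2 with its limit of > 50000 nM and a further limit may well be all that is reported. Compound 3 is estimated at 50000 nM with an expected range from 25000 nM to 100000 nM for now.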

Compound 3, half-maximal cytotoxic concentration: > 50000 nM
Compound 3: a limit, no number; the forecaster's own chance of this, stated with the estimate: 80%; the middle value sits exactly at the limit.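

Compound 2 and compound 3 each give a limit of the assay and not a number, so the change from methoxy to ethoxy shows no step that can be read: the limit of > 50000 nM in this assay, at which 3 of the 3 values shown sit.

The compounds shown leave open whether that change alters tolerance at all, since none of them yields an actual number in this assay.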